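Isopropyl in place of pyridin-2-ylmethyl on the benzimidazole nitrogen

The source may hold more compounds than are shown below. What is called first, only, known or untested is meant among the compounds shown, and "the series" means these compounds.

Measured compounds:
compound 1 `CCn1c(SCc2cc([N+](=O)[O-])ccc2OC)nc2cc(NC(=O)NC(C)(C)C)ccc21`, 42 nM in an assay on isolated protein for inhibition of Gonadotropin-releasing hormone receptor (Homo sapiens); on this read-out higher numbers stand for weaker inhibition and lower numbers for stronger inhibition
compound 2 `CCCCn1c(SCc2cc([N+](=O)[O-])ccc2OC)nc2cc(NC(=O)NC(C)(C)C)ccc21`, 23 nM
compound 3 `COc1ccc([N+](=O)[O-])cc1CSc1nc2cc(NC(=O)NC(C)(C)C)ccc2n1Cc1ccccn1`, 43 nM

Compound 3 sits within the scatter of both others: the nearest value is that of compound 1, with a 1.0-fold higher number from compound 1 to compound 3 (0.01 log units; within the scatter), and the furthest is that of compound 2, with a 1.9-fold higher number from compound 2 to compound 3 (0.27 log units; within the scatter). Compound 4 `COc1ccc([N+](=O)[O-])cc1CSc1nc2cc(NC(=O)NC(C)(C)C)ccc2n1C(C)C` differs from compound 3 by isopropyl in place of (pyridin-2-yl)methyl on an aromatic nitrogen. Going by the values given here, the steps that bear on this change are those that vary the same substituent on the aromatic nitrogen, a 1.0-fold higher number from compound 1 to compound 3 (0.01 log units; within the scatter), a 1.9-fold higher number from compound 2 to compound 3 (0.27 log units; within the scatter) and a 1.8-fold lower number from compound 1 to compound 2 (0.26 log units; within the scatter), none of which leaves the scatter. A small alkyl group in this place therefore is expected to give no step beyond the scatter in this assay, perhaps a slightly lower number. Compound 4 is estimated at 30 nM, with a range of 12 nM to 75 nM, meaning an expected 1.4-fold lower number from compound 3 to compound 4 (0.16 log units; within the scatter).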

Compound 4, half-maximal inhibitory concentration: 62 nM
Estimate against measurement, compound 4: 2.1-fold (0.32 log units) below; low and high end bracket the measured number.
By their numbers in this assay, from the lowest: compounds 2, 1, 3 and 4 (each within the scatter of the next, the first and the last beyond it).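

In this assay, going by these compounds alone, the change to isopropyl gives the only step at this aromatic nitrogen that leaves the scatter, (a 2.7-fold higher number from compound 2 to compound 4 (0.43 log units; beyond the scatter)), and this step is modest. The other two new steps, (a 1.4-fold higher number from compound 3 to compound 4 (0.16 log units; within the scatter)) and (a 1.5-fold higher number from compound 1 to compound 4 (0.17 log units; within the scatter)), stay within the scatter, so isopropyl can be told apart from butyl but not from (pyridin-2-yl)methyl or ethyl. Nothing measured here accounts for the step from butyl. The compounds shown leave open how a chain longer than butyl, or an amine or a carboxylic acid carried on this nitrogen, would read in this assay here.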